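Switching an aryl for a benzyl on a triazole nitrogen

The source may hold more compounds than are shown below. What is called first, only, known or untested is meant among the compounds shown, and "the series" means these compounds.

Compound 1 `CC(C)(C)OC(=O)N1CCN(C(=S)SCc2cn(-c3ccccc3F)nn2)CC1` was tested in a functional assay on ECa-109 cells (Homo sapiens) for inhibition, read by MTT assay, with a stated time of 72 h; on this read-out higher numbers stand for weaker inhibition and lower numbers for stronger inhibition. In this assay compound 1 gives > 128000 nM, which is a limit of the assay rather than a number. Compound 2 `S=C(SCc1cn(Cc2ccc(Cl)c(Cl)c2)nn1)N1CCNCC1` stands in the same position: in this assay compound 2 gives > 128000 nM, again a limit. Both values shown thus sit at the limit of > 128000 nM in this assay, at which 2 of the 2 values shown sit, and compound 1 cannot be ranked against compound 2 on these numbers.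

Compound 3 `CC(C)(C)OC(=O)N1CCN(C(=S)SCc2cn(Cc3ccccc3Cl)nn2)CC1` differs from compound 1 in one place: 2-chlorobenzyl in place of 2-fluorophenyl on an aromatic nitrogen. Among the measured compounds shown here, no step between two measured compounds is available in this set, so no measured size of change can be attached to this exchange. Since both values shown sit at the limit of > 128000 nM in this assay, at which 2 of the 2 values shown sit, the step from compound 1 to compound 3 is expected to be a step that the limit leaves unreadable from compound 1 to compound 3, no change beyond the scatter. Compound 3 is therefore estimated at 150000 nM, in the range 60000 nM to 400000 nM.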

Compound 3, half-maximal inhibitory concentration: 11900 nM
Compound 3: the middle estimate sits 13-fold (1.10 log units) above what was measured; the whole stated range lies above it.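

In this assay, placing 2-chlorobenzyl in place of 2-fluorophenyl on this aromatic nitrogen gives an at least 10-fold lower number from compound 1 to compound 3 (1.03 log units; beyond the scatter), so this position can move the read-out off the limit and the shared core can give a measurable value. Compound 3 is the first compound shown with a true number rather than a limit, and the result holds for this one pair, not for benzyl groups in general. The step can be given only as a minimum, since one end of it is a limit: the limit of > 128000 nM in this assay, at which 2 of the 3 values shown sit.

The exchange changes the halogen and adds a carbon link in a single step, and the compounds shown do not separate these two changes. As far as these compounds go, whether 2-fluorobenzyl, 2-chlorophenyl or a longer chain such as 2-(2-chlorophenyl)ethyl would behave like compound 3 remains open.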